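Swapping propyl for 2-hydroxyethyl on an amine nitrogen

This account rests on a few compounds, and the source may have more. Where it says the series, first, only, none or still open, it means among the compounds named here.

Measured in a functional assay on HCT-116 cells (Homo sapiens) for inhibition; on this read-out lower numbers stand for stronger inhibition and higher numbers for weaker inhibition:
- compound 1 `CCNC(=O)c1noc(-c2cc(C(C)C)c(O)cc2O)c1-c1cc(COCC(=O)OC)no1` gives 262 nM
- compound 2 `CCNC(=O)c1noc(-c2cc(C(C)C)c(O)cc2O)c1-c1cc(CN)no1` gives 84 nM
- compound 3 `CCCNCc1cc(-c2c(C(=O)NCC)noc2-c2cc(C(C)C)c(O)cc2O)on1` gives 117 nM

Compound 3 cannot be told apart from compound 2, and both sit clearly under compound 1. The numbers show a 2.2-fold lower number from compound 1 to compound 3 (0.35 log units; beyond the scatter), and a similar move in a 3.1-fold lower number from compound 1 to compound 2 (0.49 log units; beyond the scatter). Those two steps replace a different group on the same chain carbon, so they say little about the change at hand.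

Compound 4 `CCNC(=O)c1noc(-c2cc(C(C)C)c(O)cc2O)c1-c1cc(CNCCO)no1` keeps everything in compound 3 except one spot, with hydroxy in place of methyl on a saturated chain carbon, two bonds along the chain from an amine nitrogen. Propylamino thus becomes (2-hydroxyethyl)amino.

Within the data shown here, no measured pair makes this exact swap. The nearest evidence is a 1.4-fold higher number from compound 2 to compound 3 (0.14 log units; within the scatter), where adding the whole propyl chain to the amine nitrogen left the number within the scatter. A smaller edit on that same chain is therefore expected to produce no step beyond the scatter in this assay, though the missing direct comparison keeps the range wide.

The expected change is a 1.2-fold lower number from compound 3 to compound 4 (0.07 log units; within the scatter).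

For compound 4 the estimate is 100 nM, with an expected range from 45 nM to 220 nM.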

Compound 4, half-maximal inhibitory concentration: 111 nM
Compound 4: middle estimate off by 1.1-fold (0.05 log units), on the low side; the measured number falls inside the stated range.
By their numbers in this assay, from the lowest: compounds 2, 4 and 3 (each within the scatter of the next); then compound 1.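

In this assay, the direct change from propyl to 2-hydroxyethyl on the amine nitrogen gives a step that stays within the scatter (a 1.1-fold lower number from compound 3 to compound 4 (0.02 log units; within the scatter)), so this position accepts hydroxy in place of methyl with no measurable shift. The same holds against the plain amino group (a 1.3-fold higher number from compound 2 to compound 4 (0.12 log units; within the scatter)), which makes 2-hydroxyethyl the second chain on this nitrogen, after propyl, to stay within the scatter of the unsubstituted amine. The advantage over the (methoxycarbonyl)methoxy group also persists (a 2.4-fold lower number from compound 1 to compound 4 (0.37 log units; beyond the scatter)), so amino, propylamino and (2-hydroxyethyl)amino all sit clearly under the ester-bearing compound. Nothing measured here explains why the swap leaves the number in place.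

The compounds shown leave open whether this tolerance reaches further, for instance to a longer chain such as butyl on the amine nitrogen, a carboxylic acid at the chain end, or a ring amine such as morpholine. They also leave open whether a methoxy group at the end of the chain would behave like hydroxy or methyl at this position.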